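The source may hold more compounds than are shown below. What is called first, only, known or untested is meant among the compounds shown, and "the series" means these compounds.

In a functional assay on KB cells (Homo sapiens) for antiproliferative activity, read by sulforhodamine B assay, with a stated time of 3 days (on this read-out higher numbers stand for an effect only at larger amounts of compound and lower numbers for an effect already at smaller amounts), compound 1 (`CCC1=C(O)c2c(oc(-c3ccc(CBr)cc3)cc2=O)C(CC)(CC)C1=O`) gives > 46.5 uM as a limit of the assay and not a number. Among the measured compounds shown here, compound 2 (`CCC1=C(O)c2c(oc(-c3ccc(C)c(C)c3)cc2=O)C(CC)(CC)C1=O`) gives 35.5 uM in this assay as the only actual number so far, so it cannot yet be ranked. For the measured compounds named here, compound 3 (`CCC1=C(O)c2c(oc(-c3ccc(C)c(F)c3)cc2=O)C(CC)(CC)C1=O`) has fluoro in place of methyl on an aromatic carbon as its one change, ortho to a methyl group and meta to a large group. Going by the values given here, the sole measured step shows an at least 1.3-fold lower number from compound 1 to compound 2 (0.11 log units; that floor lies within the scatter) and concerns a different exchange, 3,4-dimethylphenyl in place of 4-(bromomethyl)phenyl, so it gives no size for this change. No shift beyond the scatter is therefore expected in this assay, and the expected step is a 1.1-fold lower number from compound 2 to compound 3 (0.05 log units; within the scatter) in that assay. For compound 3 the estimate is 32 uM with an expected range from 14 uM to 60 uM in this read-out.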

Compound 3, concentration for half-maximal effect: 28.1 uM
Compound 3: middle estimate off by 1.1-fold (0.06 log units), on the high side; low and high end bracket the measured number.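

At the aromatic carbon ortho to a methyl group and meta to a large group, fluoro in place of methyl gives a 1.3-fold lower number from compound 2 to compound 3 (0.10 log units; within the scatter) in this assay, so this exchange leaves the two values indistinguishable. It is the only step shown that joins two actual numbers, and it gives this change a size that the earlier compounds could not. The step with 3-fluoro-4-methylphenyl in place of 4-(bromomethyl)phenyl reads an at least 1.6-fold lower number from compound 1 to compound 3 (0.21 log units; that floor lies within the scatter) and remains only a floor because its starting value is a limit of the assay and not a number: the limit of > 46.5 uM in this assay, at which 1 of the 3 values shown sits.

As far as these compounds go, whether an amine, a carboxylic acid or a methoxy group at this place would move the number beyond the scatter stays open. The same holds for chloro or a longer chain such as propyl.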